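Amide Substituent Change in a Nerve Growth Factor Receptor Series

The source may hold more compounds than are shown below. What is called first, only, known or untested is meant among the compounds shown, and "the series" means these compounds.

Compound 1 `CN(CCCn1ccnc1)C(=O)[C@@H]1CCCN1c1nccc(Nc2ccccc2)n1`: 11%
Compound 2 `Cc1cccc(Nc2ncnc3c2CN(C(=O)c2ccc(N(C)C)c4ccccc24)CC3)c1`: 8%

Of the compounds shown here, two have been measured in an assay on isolated protein for inhibition of high affinity nerve growth factor receptor (Homo sapiens), read by HTRF, tested at 10 uM; on this read-out lower numbers stand for less inhibition and higher numbers for more inhibition at the one concentration tested (going by the name of the read-out). Compound 1 gives 11% in this assay, the higher of the two numbers, and compound 2 gives 8%; the two lie within the scatter of each other, so no order between them can be claimed, and both numbers are low. Compound 3 `COC[C@@H]1CCCN1C(=O)[C@@H]1CCCN1c1nccc(Nc2ccccc2)n1` is a close relative of compound 1. The change is 2-(methoxymethyl)pyrrolidin-1-yl in place of (3-(1H-imidazol-1-yl)propyl)(methyl)amino on a carbonyl carbon. For the measured compounds named here, both measured compounds sit near the bottom of the read-out, and no step between measured compounds is known that would suggest a change of this kind shifts inhibition strongly. Compound 3 is therefore expected to give a number at the same low level, with a number 1 percentage points lower from compound 1 to compound 3 (within the scatter) amounting to no step beyond the scatter. The estimated value for compound 3 in this assay is 10%, within a range of 0% to 28%.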

Compound 3, a percentage reported as inhibition, at one concentration (the size of the read-out at that concentration, not a potency): 8%
For compound 3 the middle estimate is 2 percentage points above the measured one, within the range that was stated.
By their numbers in this assay, from the lowest: compounds 2, 3 and 1 (each within the scatter of the next).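

In this assay, for the compounds shown here, 2-(methoxymethyl)pyrrolidin-1-yl in place of (3-(1H-imidazol-1-yl)propyl)(methyl)amino on the carbonyl carbon gives a number 3 percentage points lower from compound 1 to compound 3 (within the scatter) and is the only step available at this position. A five-membered aromatic ring with 2 hetero atoms thus gives way to a five-membered non-aromatic ring with 1 hetero atom and a defined stereocentre, with no difference that this read-out can separate, and both numbers remain low at the one concentration tested. No measured information is available to explain this result.

Going by these compounds, whether a primary amine, a carboxylic acid or a longer chain on this carbonyl carbon would bring a step beyond the scatter remains open. So does what the opposite stereoisomer of the 2-(methoxymethyl)pyrrolidin-1-yl group would give, and whether changes elsewhere on the shared core would matter more.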